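Amide replacement in an aminoquinoline ether series

The source may report more compounds than this note shows. Statements on the series, on what has been measured and on what is new or still open speak of the compounds shown alone.

Measured compounds:
- compound 1 `COc1cccc(CNCC(C)Oc2cccc3ccc(N)nc23)c1` — in a functional assay on IMR-32 cells with melanin-concentrating hormone receptor 1 (Homo sapiens) as the target, read by fluorescence (on this read-out lower numbers stand for stronger inhibition and higher numbers for weaker inhibition), compound 1 gives 600 nM
- compound 2 `CC(C)c1ccc(C(=O)NCCCOc2cccc3ccc(N)nc23)cc1` — in this assay compound 2 gives 140 nM

Of the two numbers shown, compound 2 has the lower one. Compound 1 sits higher, and the gap between the two values is beyond the usual scatter of repeated runs, so compound 2 is the stronger inhibitor of the pair as far as these two measurements go. The two compounds differ in more than one place (a benzylamine linker in compound 1 against an amide linker in compound 2, and a different substitution on the phenyl ring), so no single step can be read from them.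

Compound 3 `COc1cccc(C(=O)NCCCOc2cccc3ccc(N)nc23)c1` has not been measured. Relative to compound 2 the change is 3-methoxyphenyl in place of 4-isopropylphenyl on a carbonyl carbon. Among the compounds with values here, no measured pair isolates this change. The expectation is a step from compound 2 to compound 3 of a 2.9-fold higher number from compound 2 to compound 3 (0.46 log units; beyond the scatter), towards a higher number, of a size that may reach beyond the scatter. For compound 3 the estimated value in this assay is 400 nM, with a range from 120 nM to 1500 nM.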

Compound 3, half-maximal inhibitory concentration: 30 nM
Compound 3: the middle estimate sits 13-fold (1.12 log units) above what was measured; measured number outside the range, below it.
By their numbers in this assay, from the lowest: compound 3; then compound 2; then compound 1.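

Within the data shown here, on the carbonyl carbon of the amide, 3-methoxyphenyl in place of 4-isopropylphenyl gives a 4.7-fold lower number from compound 2 to compound 3 (0.67 log units; beyond the scatter) in this assay, a step beyond the scatter and the first change that can be read in one place. It shows that the aryl group on this carbonyl carbon affects the read-out with the amide linker held constant, something the pair of compound 1 and compound 2 could not show with two places changed at once. Nothing in the data shown accounts for the size or direction of this step.

On these data alone, the step combines a change of substituent with a change in its place on the phenyl ring, so it remains open which of the two carries the effect, and whether the step would hold with the benzylamine linker of compound 1. Also open, as far as these compounds go, is how this carbonyl position would respond to an amine or a carboxylic acid on the phenyl ring, and how the series would respond to a longer chain in the linker.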